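The source may report more compounds than this note shows. Statements on the series, on what has been measured and on what is new or still open speak of the compounds shown alone.

Measured so far:
Compound 1, `Cc1ccccc1-c1cc(C#Cc2ccc(CCC(=O)O)cc2)ccn1`: 1070 nM
Compound 2, `Cc1cc(C#Cc2ccc(CCC(=O)O)cc2)nc(Cl)n1`: 2750 nM

Among the compounds with values here, in an in vitro functional assay on 1321-N1 cells for agonist activity at Free fatty acid receptor 1 (Homo sapiens), read by fluorescence, spectrophotometry and calcium flux (a lower number here means that less compound is needed, a higher number that more compound is needed for the effect), compound 1 gives 1070 nM, the lower of the two numbers measured so far; compound 2 gives 2750 nM in this assay, a higher number, and the gap between them lies beyond the usual scatter. Compound 3, `O=C(O)CCc1ccc(C#Cc2ccnc(-c3ccccc3)c2)cc1`, has not yet been measured. It differs from compound 1 in one place: hydrogen in place of methyl on an aromatic carbon, at a position described as ortho to a large group. Within the data shown here, no measured pair in this set shows the effect of this change, so there is no directly comparable step to lean on. The expectation is a small step, if any, probably toward a slightly higher number and close to the scatter. Starting from compound 1 with 1070 nM, the estimated step is a 1.5-fold higher number from compound 1 to compound 3 (0.17 log units; within the scatter). Compound 3 is therefore expected to give about 1600 nM in this assay, within a range of 600 nM to 4500 nM.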

Compound 3, half-maximal effective concentration: 186 nM
Compound 3: the middle estimate sits 8.6-fold (0.93 log units) above what was measured; the whole stated range lies above it.
By their numbers in this assay, from the lowest: compound 3; then compound 1; then compound 2.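

In this assay the change from 2-methylphenyl to phenyl gives a 5.8-fold lower number from compound 1 to compound 3 (0.76 log units; beyond the scatter) and so shows that this place on the ring is sensitive to a very small edit. Losing a single carbon, with hydrogen in place of methyl on an aromatic carbon ortho to a large group, is enough to move the number well beyond the usual scatter, and the simpler phenyl compound is the one that needs less compound for the effect. Nothing available here explains why the methyl and the hydrogen differ in this way.

This single pair is all that speaks to the position, so it gives a direction for one change and no trend. On these data alone, whether a fluorine atom, a methoxy group or an ethyl group at this place would behave more like the hydrogen or more like the methyl stays open.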